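Cytotoxicity notes on a shared-core series

The source may hold more compounds than are shown below. What is called first, only, known or untested is meant among the compounds shown, and "the series" means these compounds.

compound 1 `c1ccc(CNc2c(-c3ccccn3)nc3ccccn23)cc1`: > 50000 nM
compound 2 `Fc1cccc(Nc2c(-c3ccccn3)nc3ccccn23)c1`: > 50000 nM

In an ADME assay on THP-1 cells (Homo sapiens) for cytotoxicity (on this read-out higher numbers stand for lower toxicity in this test and lower numbers for higher toxicity in this test), compound 1 gives > 50000 nM, which is a limit of the assay, not a number. Compound 2 gives > 50000 nM, likewise a limit. The step that the two limits leave unreadable from compound 1 to compound 2 therefore has no readable size. For the measured compounds named here, compound 2 thus stands only at a limit in this assay; the one thing the measured values show is the limit of > 50000 nM in this assay, at which 2 of the 2 values shown sit.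

Compound 3 `CN(C)Cc1ccn2c(Nc3cccc(F)c3)c(-c3ccccn3)nc2c1` differs from compound 2 by (dimethylamino)methyl in place of hydrogen on an aromatic carbon. Going by the values given here, no measured step bears on a change of this kind, and the single measured step gives no size. Compound 3 is expected to remain at or near the limit, and the expected step is a step that the limit leaves unreadable from compound 2 to compound 3. Compound 3 is estimated at 60000 nM, with a range of 20000 nM to 200000 nM.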

Compound 3, half-maximal cytotoxic concentration: 33300 nM
The estimate for compound 3 lay 1.8-fold (0.26 log units) above the measured number; measured number inside the range.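

In this assay, (dimethylamino)methyl in place of hydrogen on an aromatic carbon, opposite the ring nitrogen, gives the series its first value that is a number and not a limit. The change gives an at least 1.5-fold lower number from compound 2 to compound 3 (0.17 log units; that floor lies within the scatter). On these data alone, only this floor can be read, and the true size of the step remains unknown, as the comparison starts from a limit: the limit of > 50000 nM in this assay, at which 2 of the 3 values shown sit.

As far as these compounds go, how a plain methyl, a morpholinomethyl or a carboxylic acid at this position would read remains open. So does the effect of (dimethylamino)methyl on compound 1.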